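This account rests on a few compounds, and the source may have more. Where it says the series, first, only, none or still open, it means among the compounds named here.

Measured so far in an assay on Jurkat T cells for inhibition of interleukin-2 (Homo sapiens), read by ELISA, with stated times of 10 min and 24 h; on this read-out lower numbers stand for stronger inhibition and higher numbers for weaker inhibition:
- compound 1, `Cc1ccc(C2=NOC(C)(C)C2=O)cc1-c1cnc(NC(=O)c2c(F)cccc2F)cn1`: 34 nM
- compound 2, `Cc1ccc(C2=NOC(C)(C)C2=O)cc1-c1cnc(NC(=O)c2ccccc2Cl)cn1`: 171 nM

Compound 2 gives the highest of the two numbers in this assay, which on this read-out means the weaker inhibition of the pair. For the measured compounds named here, its one neighbour is compound 1, reached by the single swap of 2-chlorophenyl in place of 2,6-difluorophenyl on the carbonyl carbon, and that step showed a 5.0-fold higher number from compound 1 to compound 2 (0.70 log units; beyond the scatter).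

Compound 3, `Cc1ccc(C2=NOC(C)(C)C2=O)cc1-c1cnc(NC(=O)c2c(F)cccc2Cl)cn1`, has not yet been measured. It differs from compound 2 by fluoro in place of hydrogen on an aromatic carbon, the change being placed on an aromatic carbon of a six-membered aromatic ring of carbon only; read one bond further out, the ring goes from 2-chlorophenyl to 2-chloro-6-fluorophenyl.

Going by the values given here, only the step from compound 1 to compound 2 bears on this, and it ran the other way, removing fluorine from that ring while the number rose. Putting one fluorine back is therefore expected to lower the number, with a step estimated at a 2.9-fold lower number from compound 2 to compound 3 (0.45 log units; beyond the scatter), though probably not all the way back to compound 1. For compound 3 the expected value in this assay is 60 nM, within a range from 25 nM to 150 nM.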

Compound 3, half-maximal inhibitory concentration: 64.8 nM
Estimate against measurement, compound 3: 1.1-fold (0.03 log units) below, within the range that was stated.
By their numbers in this assay, from the lowest: compounds 1 and 3 (each within the scatter of the next); then compound 2.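

In this assay, fluoro on the aromatic carbon ortho to a large group, with the chloro group left in place, gives a 2.6-fold lower number from compound 2 to compound 3 (0.42 log units; beyond the scatter), so this single added atom is enough to move the number beyond the scatter. The earlier step could not show this, since a 5.0-fold higher number from compound 1 to compound 2 (0.70 log units; beyond the scatter) combined the loss of one fluoro group with the exchange of the other for chloro. Set against that, a 1.9-fold higher number from compound 1 to compound 3 (0.28 log units; within the scatter) stays within the scatter, so in these three compounds the clear gap lies between the 2-chlorophenyl ring of compound 2 and the two rings carrying two halogens, and no evidence here explains that gap.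

The compounds shown leave open whether a larger halogen such as a second chloro, or a non-halogen group such as methyl or methoxy, would serve on this carbon as fluoro does. They also leave open how a 2-fluorophenyl ring, with fluoro as its only halogen, would compare, and so whether the chloro group contributes anything of its own.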